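Swapping a Nitro for a Bromo on the Benzoxazole Core

This account rests on a few compounds, and the source may have more. Where it says the series, first, only, none or still open, it means among the compounds named here.

Measured so far:
compound 1 `O=C(CCCCCc1ccccc1)c1nc2ncccc2[nH]1` gives 1230 nM
compound 2 `O=C(CCCCCc1ccccc1)c1nc2ccc(F)cc2o1` gives 708 nM
compound 3 `O=C(CCCCCc1ccccc1)c1nc2ccc([N+](=O)[O-])cc2o1` gives 87.1 nM

All three compounds share the same phenyl-bearing chain ending in a carbonyl, and were tested in an assay on HEK-293T cells for inhibition of diacylglycerol lipase-alpha (Homo sapiens), read by colorimetric assay; a lower number here means a stronger inhibitor, a higher number a weaker inhibitor. Compound 3 stands lowest of the three numbers; its nearest neighbour is compound 2, and compound 1 lies furthest away. Going by the values given here, the only single-point step among the measured compounds runs an 8.1-fold lower number from compound 2 to compound 3 (0.91 log units; beyond the scatter), which shows that the group at this position matters for the read-out.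

Compound 4 `O=C(CCCCCc1ccccc1)c1nc2ccc(Br)cc2o1` has not yet been measured. It differs from compound 3 in one place: bromo in place of nitro on an aromatic carbon. Among the compounds with values here, the measured step that bears on this change is the one from compound 2 to compound 3, since it swaps a halogen against the nitro at the same position, and bromo is also a halogen. The nitro-for-fluoro step lowered the number beyond the scatter; taking the nitro out again and putting in a different halogen is therefore expected to move the number back upward, though bromo is not fluoro, so the size of the return is uncertain. The step from compound 3 to compound 4 is expected to be a 3.4-fold higher number from compound 3 to compound 4 (0.54 log units; beyond the scatter). Compound 4 is estimated at 300 nM, with a range from 120 nM to 800 nM.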

Compound 4, half-maximal inhibitory concentration: 5890 nM
Compound 4: middle estimate off by 20-fold (1.29 log units), on the low side; the whole stated range lies below it.
By their numbers in this assay, from the lowest: compound 3; then compounds 2 and 1 (each within the scatter of the next); then compound 4.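

Putting bromo in place of nitro on this aromatic carbon gives a 68-fold higher number from compound 3 to compound 4 (1.83 log units; beyond the scatter) in this assay, so the low number of compound 3 does not carry over to this bromo compound. The comparison between the two halogens adds something new: an 8.3-fold higher number from compound 2 to compound 4 (0.92 log units; beyond the scatter), so at this carbon one halogen cannot be treated as a stand-in for another. Across the three compounds that differ only in this group, the numbers rise in the order nitro, fluoro, bromo, with each of the steps lying beyond the usual scatter, which makes this single carbon a sensitive point on the shared core.

From the compounds shown here alone, whether an amine, a nitrile, a carboxylic acid or a chloro group at this carbon would give a number closer to that of compound 3 or that of compound 4 remains open, and three groups are too few to predict it. No measured property of the nitro, fluoro or bromo groups accompanies these numbers, so the data offer no explanation for this order.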